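The source may report more compounds than this note shows. Statements on the series, on what has been measured and on what is new or still open speak of the compounds shown alone.

Measured so far:
- compound 1, `CC(C)CCCOc1cccc(O)c1C(=O)/C=C/c1ccc(O)cc1`, 3600 nM
- compound 2, `CC(C)(C)CCOc1cccc(O)c1C(=O)/C=C/c1ccc(O)cc1`, 3220 nM
- compound 3, `CC(C)COc1cccc(O)c1C(=O)/C=C/c1ccc(O)cc1`, 2970 nM

These three compounds were tested in a functional assay on PC-3 cells (Homo sapiens) for antiproliferative activity, read by sulforhodamine B assay; a higher number here means a weaker inhibitor of growth, a lower number a stronger inhibitor of growth. Compound 1 gives the highest of the three numbers, but only by a little: the step of a 1.1-fold lower number from compound 1 to compound 2 (0.05 log units; within the scatter) and the step of a 1.2-fold lower number from compound 1 to compound 3 (0.08 log units; within the scatter) both fall within the scatter, as does a 1.1-fold lower number from compound 2 to compound 3 (0.04 log units; within the scatter). All three compounds therefore sit at the same level as far as this assay can tell.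

Compound 4, `O=C(/C=C/c1ccc(O)cc1)c1c(O)cccc1OCc1ccccc1`, has not been measured. It differs from compound 1 in one place: phenyl in place of isopentyl on a saturated chain carbon bound to an oxygen on an aromatic ring. The measured steps all swap one saturated chain for another at this position, and none of them moved the number beyond the scatter. For the measured compounds named here, a phenyl ring is a different kind of group, and no measured step tests it, so the expectation rests on the indifference seen so far. The step of a 1.2-fold lower number from compound 1 to compound 4 (0.08 log units; within the scatter) is expected to stay within the scatter. Compound 4 is thus estimated at 3000 nM, with a range from 1200 nM to 8000 nM.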

Compound 4, concentration for 50% growth inhibition: > 30000 nM
Compound 4: a limit, no number; the forecaster's own chance of this, stated with the estimate: 5%; middle value at least 10-fold (1.00 log units) from the limit.
By their numbers in this assay, from the lowest: compounds 3, 2 and 1 (each within the scatter of the next). At a limit, above all of these: compound 4.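

Compound 4 carries a limit of the assay, not a number: the limit of > 30000 nM in this assay, at which 1 of the 4 values shown sits. Even so, all three steps in this assay are beyond the scatter: an at least 8.3-fold higher number from compound 1 to compound 4 (0.92 log units; beyond the scatter), an at least 9.3-fold higher number from compound 2 to compound 4 (0.96 log units; beyond the scatter) and an at least 10-fold higher number from compound 3 to compound 4 (1.00 log units; beyond the scatter). The position that seemed indifferent while only saturated chains were swapped therefore does respond to the group placed there, since phenyl in place of these chains costs growth inhibition even though neither kind of group has any hydrogen-bond donors or acceptors.

On these data alone, whether the loss follows from having a ring at all or from its being aromatic stays open, and cyclohexyl in the same place would separate these two readings. Also open, as far as these compounds go, are how far the true value of compound 4 lies from its limit and whether a pyridine ring would behave like phenyl.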